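Cytotoxicity notes: biaryl extension of compound 2

A few compounds are considered here, and "the series" means these few. Any claim that something is new, unique, unknown or untested is made for them only; others in the source may bear on it.

Measured compounds: compound 1 `N/C(=N/O)c1ccc(C2=C(S(=O)(=O)c3ccc(F)cc3)CC(c3ccccc3)(c3ccccc3)O2)cc1` gives 19200 nM; compound 2 `CC1(c2ccccc2)CC(S(=O)(=O)c2ccc(F)cc2)=C(c2ccc(/C(N)=N\O)cc2)O1` gives 68300 nM.

For the measured compounds named here, in an ADME assay on HepG2 cells (Homo sapiens) for cytotoxicity, read by MTT assay, with a stated time of 72 h (a higher number here means that more compound is tolerated, a lower number that less compound is tolerated), compound 2 holds the highest of the two numbers; the only step, a 3.6-fold higher number from compound 1 to compound 2 (0.55 log units; beyond the scatter), is what separates it from compound 1.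

Compound 3 `Cc1ccc(-c2ccc(C3(C)CC(S(=O)(=O)c4ccc(F)cc4)=C(c4ccc(/C(N)=N\O)cc4)O3)cc2)cc1` carries the change (4-methylphenyl in place of hydrogen on an aromatic carbon). Going by the values given here, no measured step touches this aromatic carbon; the single known step concerns a saturated ring carbon, so it gives no direct guide. Compound 3 is expected to show a 2.3-fold lower number from compound 2 to compound 3 (0.36 log units; beyond the scatter), a lower number within a wide band. The estimate for compound 3 is 30000 nM, range 10000 nM to 90000 nM.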

Compound 3, half-maximal cytotoxic concentration: 13700 nM
Estimate against measurement, compound 3: 2.2-fold (0.34 log units) above; low and high end bracket the measured number.
By their numbers in this assay, from the lowest: compounds 3 and 1 (each within the scatter of the next); then compound 2.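

In this assay, for the compounds shown here, the first change at this aromatic carbon gives a 5.0-fold lower number from compound 2 to compound 3 (0.70 log units; beyond the scatter) when 4-methylphenyl replaces hydrogen. The earlier step concerned a saturated ring carbon; this one shows that substitution at the aromatic carbon also lowers the tolerated concentration, by a modest step beyond the scatter. No available evidence accounts for this drop. One substituent at this carbon cannot separate the contribution of the added ring from that of its methyl. Plain phenyl, an amine or a carboxylic acid at the same carbon remains open.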